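Methoxy for methyl on the aryl group of compound 3

This account rests on a few compounds, and the source may have more. Where it says the series, first, only, none or still open, it means among the compounds named here.

Within the data shown here, compound 3 `COc1cc(N2C(N)=C(C#N)C(c3ccc(C)cc3)C3=C2CC(C)(C)CC3=O)cc(OC)c1OC` gives 60% in a functional assay on Ehrlich cells (Mus musculus) for cytotoxicity, tested at 50 ug/mL (a lower number here means a weaker effect, a higher number a stronger effect of the compound at the concentration tested), the highest of the three numbers known here, while compound 1 `COc1cc(N2C(N)=C(C#N)C(c3ccc(OC)c4ccccc34)C3=C2CC(C)(C)CC3=O)cc(OC)c1OC` gives 40% and compound 2 `COc1cc(N2C(N)=C(C#N)C(c3ccccc3Cl)C3=C2CC(C)(C)CC3=O)cc(OC)c1OC` gives 20%. The steps toward compound 3 are a number 20 percentage points higher from compound 1 to compound 3 (beyond the scatter) and a number 40 percentage points higher from compound 2 to compound 3 (beyond the scatter), and between the other two a number 20 percentage points lower from compound 1 to compound 2 (beyond the scatter). Compound 4 `COc1ccc(C2C(C#N)=C(N)N(c3cc(OC)c(OC)c(OC)c3)C3=C2C(=O)CC(C)(C)C3)cc1` differs from compound 3 by methoxy in place of methyl on an aromatic carbon. Among the measured compounds shown here, every measured step exchanges the whole aryl group on the saturated ring carbon; none exchanges a single substituent on that aromatic ring, so no step bears directly on this change, and the swings seen between different aryl groups do not say how a smaller change will read. One therefore expects no step beyond the scatter, a number 10 percentage points lower from compound 3 to compound 4 (within the scatter), and estimates compound 4 at 50%, within 30% to 70%.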

Compound 4, a percentage reported as activity, at one concentration (the size of the read-out at that concentration, not a potency): 11%
Estimate against measurement, compound 4: 39 percentage points above; the measured number lies below the stated range.
By their numbers in this assay, from the lowest: compounds 4 and 2 (each within the scatter of the next); then compound 1; then compound 3.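

In this assay, the step from methyl to methoxy on the aromatic carbon para to a large group gives a number 49 percentage points lower from compound 3 to compound 4 (beyond the scatter), showing that this single substituent can move the read-out about as far as exchanging a whole aryl group. With the aryl group exchanged, the 4-methoxyphenyl compound shows a number 9 percentage points lower from compound 2 to compound 4 (within the scatter) and a number 29 percentage points lower from compound 1 to compound 4 (beyond the scatter). Nothing available explains the large methyl-to-methoxy step.

The compounds shown leave open how an ethyl, hydroxyl or dimethylamino group would read at this place. They also leave open whether methoxy would give a similar step on another aromatic carbon.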